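Aryl exchange on the shared core: partition notes

This account rests on a few compounds, and the source may have more. Where it says the series, first, only, none or still open, it means among the compounds named here.

Measured so far in a physicochemical assay for lipophilicity, using the shake flask method, in phosphate buffer, measured as octanol-water partition, with a stated time of 85 min, at pH 7.4; a lower number here means a more polar compound, a higher number a more lipophilic compound:
compound 1 `c1cn2cc(-c3ccsc3)nc(-c3ccc4ncn(C5CCCCC5)c4c3)c2n1` gives 1.81
compound 2 `CC(=O)c1ccc(-c2cn3ccnc3c(-c3ccc4ncn(C5CCCCC5)c4c3)n2)cc1` gives 2.06

For the measured compounds named here, compound 2 holds the higher of the two numbers; its nearest neighbour is compound 1, and the only measured step, a number 0.25 log units higher from compound 1 to compound 2 (within the scatter), stays within the scatter, so the two values cannot be ordered.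

Compound 3 `Fc1ccccc1-c1cn2ccnc2c(-c2ccc3ncn(C4CCCCC4)c3c2)n1` awaits measurement. The change from compound 2 is 2-fluorophenyl in place of 4-acetylphenyl on an aromatic carbon. Going by the values given here, the one measured step bears on it only loosely: it exchanges the aryl group at the same position, but neither of the groups involved there appears in the present change, and its size was within the scatter, so it sets no direct precedent. What remains is the difference in what is counted: the acetyl-bearing group leaves with its hydrogen-bond acceptor and double bond outside the ring, and the entering group carries none. On that basis a moderate rise in this assay is expected, larger than the scatter.

For compound 3 the estimate is 2.65, with a range from 2.2 to 3.1. The expected step is a number 0.59 log units higher from compound 2 to compound 3 (beyond the scatter).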

Compound 3, partition coefficient: 1.95
Compound 3: the middle estimate sits 0.70 log units above what was measured; measured number outside the range, below it.
By their numbers in this assay, from the lowest: compounds 1, 3 and 2 (each within the scatter of the next).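

In this assay, the exchange at this aromatic carbon again stays within the scatter: a number 0.11 log units lower from compound 2 to compound 3 (within the scatter), and a number 0.14 log units higher from compound 1 to compound 3 (within the scatter), so compounds 1, 2 and 3 cannot be ordered by this read-out. For the compounds shown here, the change from compound 2 to compound 3 removes the carbonyl of 4-acetylphenyl, with its hydrogen-bond acceptor and its double bond outside the ring, and this is the first comparison in which such a loss can be read, yet no step beyond the scatter goes with it. Thiophen-3-yl, 4-acetylphenyl and 2-fluorophenyl therefore give numbers that lie together on the shared core, and no measurement at hand accounts for this closeness.

As far as these compounds go, all three groups at this position are uncharged aromatic rings, so it stays open whether an amine or a carboxylic acid on the aryl ring would carry the number beyond the scatter. From the compounds shown here alone, it also stays open whether a longer alkyl chain in place of the aryl group, or a change to the cyclohexyl group held constant across these compounds, would do so.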